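From trifluoromethyl to ethoxycarbonyl on an aromatic carbon

A few compounds are considered here, and "the series" means these few. Any claim that something is new, unique, unknown or untested is made for them only; others in the source may bear on it.

Compound 1 `CCN(CC)c1ccc(-c2cccc(C(F)(F)F)c2)nn1` gives > 25000 nM in an ADME assay on cells (Fibroblast, Homo sapiens) for antiproliferative activity, with a stated time of 48 h (a higher number here means a weaker inhibitor, a lower number a stronger inhibitor), which is a limit of the assay and not a number. Compound 2 `CCN(CC)c1ccc(-c2ccc(C(C)=O)cc2)nn1` gives > 25000 nM, and this too is a limit. In this assay compound 3 `CCN(CC)c1ccc(-c2ccc(C(=O)OC)cc2)nn1` gives a true number, 100 nM. Compound 4 `CCOC(=O)c1cccc(-c2ccc(N(CC)CC)nn2)c1` departs from compound 1 by ethoxycarbonyl in place of trifluoromethyl on an aromatic carbon, with ethoxycarbonyl in place of trifluoromethyl on an aromatic carbon. Among the measured compounds shown here, the one measured step that bears on this change is large: an at least 250-fold lower number from compound 2 to compound 3 (2.39 log units; beyond the scatter), with methoxy in place of methyl on a carbonyl carbon. It is only an indirect guide, as compound 3 and compound 4 differ in the chain on the carbonyl and in where the group sits. A lower number is therefore expected, though a smaller gain than that step showed, and compound 4 may yet stay at the limit. The expected change, estimated with wide uncertainty, is an at least 16-fold lower number from compound 1 to compound 4 (1.22 log units; beyond the scatter). For compound 4 the estimated value is 1500 nM, with an expected range from 150 nM to 15000 nM.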

Compound 4, half-maximal inhibitory concentration: > 25000 nM
Compound 4: only a limit was reported; the forecaster's own chance of this, stated with the estimate: 25%; middle value at least 16-fold (1.22 log units) away from the limit.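

Compound 1 and compound 4 both stand at a limit of the assay and not at a number, so the step between them cannot be read in this assay: the limit of > 25000 nM in this assay, at which 3 of the 4 values shown sit. The compounds shown leave open whether ethoxycarbonyl in place of trifluoromethyl changes the number at all.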